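This account rests on a few compounds, and the source may have more. Where it says the series, first, only, none or still open, it means among the compounds named here.

Of the compounds shown here, three have been tested, and a fourth awaits its turn. Compound 2 `Oc1ccccc1CNc1ccc(-c2ccccc2)cc1` is the only one of them with a number: in a functional assay on Jurkat cells (Homo sapiens) for activation, with a stated time of 24 h (on this read-out lower numbers stand for an effect already at smaller amounts and higher numbers for an effect only at larger amounts of compound), compound 2 gives 1820 nM. Compound 1 `CN1CCN(c2ccc(NCc3ccccc3O)cc2)CC1` was reported in this assay as "not active" (no number reported), without a number, and compound 3 `N#Cc1ccccc1-c1ccc(NCc2ccccc2O)cc1` was likewise reported in this assay as "not active" (no number reported). So compound 2 stands alone as the sole measurable result, with the two other entries giving no figure to compare against.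

Compound 4 `CCSc1ccc(-c2ccc(NCc3ccccc3O)cc2)cc1` is the next candidate. It differs from compound 2 by ethylsulfanyl in place of hydrogen on an aromatic carbon. Among the compounds with values here, no pair of measured compounds differing in a single place exists here, so the size of such a step has not been seen; the two entries without a number show only that changes elsewhere on the shared core can remove the measurable effect altogether.

With that in mind, compound 4 is expected to land near compound 2, and the step from compound 2 to compound 4 is estimated at a 1.2-fold lower number from compound 2 to compound 4 (0.08 log units; within the scatter), not clearly beyond the scatter in either direction. The estimate for compound 4 is 1500 nM, within a range from 400 nM to 6000 nM.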

Compound 4, half-maximal effective concentration: 1980 nM
Beside the measured number, compound 4's estimate is 1.3-fold (0.12 log units) below it, within the range that was stated.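

In this assay, within the data shown here, ethylsulfanyl in place of hydrogen on an aromatic carbon, para to a large group, gives a 1.1-fold higher number from compound 2 to compound 4 (0.04 log units; within the scatter), the first step in a single place seen in this set. This position therefore accepts a group of 3 heavy atoms, sulfur among them, and the measurable effect stays, with no difference that can be told from the usual scatter. Nothing measured here speaks to the reason for this result.

One group at one place cannot show how much this position accepts in general. As far as these compounds go, it remains open whether an amine, a carboxylic acid or a longer chain such as hexyl would leave the number just as unchanged here, and whether an ether oxygen in place of the sulfur would do the same.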